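This account rests on a few compounds, and the source may have more. Where it says the series, first, only, none or still open, it means among the compounds named here.

Compound 1 `CCOC(=O)N1CCC(=NNC(=O)c2ccc(F)cc2)CC1`: > 400000 nM
Compound 2 `O=C(NN=C1CC(c2ccccc2)NC(c2ccccc2)C1)c1ccccc1`: > 400000 nM

In a toxicity assay on BJ cells (Homo sapiens) for cytotoxicity, read by MTT assay, with a stated time of 24 h (on this read-out higher numbers stand for weaker inhibition and lower numbers for stronger inhibition), compound 1 returns only a limit of the assay, > 400000 nM. Compound 2 also returns only a limit, > 400000 nM. Compound 2 thus stands where every value shown stands, namely at the limit of > 400000 nM in this assay, at which 2 of the 2 values shown sit. Compound 3 `O=C(NN=C1CC(c2ccccc2)NC(c2ccccc2)C1)c1ccc(Cl)cc1` differs from compound 2 by chloro in place of hydrogen on an aromatic carbon. No measured step of this kind exists among the compounds shown, so the expected step of a number no higher from compound 2 to compound 3 (the limit leaves the size open) is taken as none beyond the scatter. Compound 3 is therefore estimated at 400000 nM, with a range from 100000 nM to 2000000 nM.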

Compound 3, half-maximal inhibitory concentration: > 400000 nM
Compound 3 was reported as a limit (the forecaster's own chance of this, stated with the estimate: 75%); the middle value lies on the limit itself.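

Compound 3 gives only a limit, > 400000 nM. Compound 2 is also a limit, so no step can be read between compound 2 and compound 3. The compounds shown leave open whether chloro in place of hydrogen changes the result in this assay, and at what concentration any of them would inhibit.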